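The source may hold more compounds than are shown below. What is called first, only, known or untested is meant among the compounds shown, and "the series" means these compounds.

Measured so far:
compound 1 `COc1ccc(-c2c(Nc3ccc(NC(C)=O)cc3)c3ccc(OC)cc3oc2=O)cc1` — in a functional assay on MCF7 cells (Homo sapiens) for antiproliferative activity, read by MTT assay, with a stated time of 48 h (a higher number here means a weaker inhibitor, a lower number a stronger inhibitor), compound 1 gives 85800 nM
compound 2 `COc1ccc(-c2c(Nc3cccc(C(F)(F)F)c3)c3ccc(OC)cc3oc2=O)cc1` — in this assay compound 2 gives 36200 nM
compound 3 `COc1ccc(-c2c(Nc3ccc(NC(C)=O)cc3)c3ccc(O)cc3oc2=O)cc1` — in this assay compound 3 gives only a limit, > 100000 nM

The change 3-(trifluoromethyl)phenyl in place of 4-acetamidophenyl on a nitrogen on an aromatic ring gave a 2.4-fold lower number from compound 1 to compound 2 (0.37 log units; beyond the scatter). The change hydrogen in place of methyl on an oxygen on an aromatic ring gave an at least 1.1-fold higher number from compound 1 to compound 3 (0.06 log units; that floor lies within the scatter), and of that step only a floor is known. The value of compound 3 is a limit of the assay (the limit of > 100000 nM in this assay, at which 1 of the 3 values shown sits).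

Compound 4 `COc1ccc(-c2c(Nc3cccc(C(F)(F)F)c3)c3ccc(O)cc3oc2=O)cc1` is not yet measured in this assay. It differs from compound 3 by 3-(trifluoromethyl)phenyl in place of 4-acetamidophenyl on a nitrogen on an aromatic ring, the same change as from compound 1 to compound 2; the shared core of compound 3 and compound 4 differs from that of compound 1 by hydrogen in place of methyl on an oxygen on an aromatic ring.

Compound 4 is expected at 60000 nM, between 25000 nM and 150000 nM. The estimate for compound 4 means an at least 1.6-fold lower number from compound 3 to compound 4 (0.22 log units; that floor lies within the scatter), expected because the same change gave a 2.4-fold lower number from compound 1 to compound 2 (0.37 log units; beyond the scatter). As compound 3 sits at a limit, compound 4 may also return only a limit.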

Compound 4, half-maximal inhibitory concentration: 49100 nM
Compound 4: middle estimate off by 1.2-fold (0.09 log units), on the high side, within the range that was stated.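

In this assay the change to 3-(trifluoromethyl)phenyl from 4-acetamidophenyl gave an at least 2.0-fold lower number from compound 3 to compound 4 (0.30 log units; that floor lies within the scatter), the same direction as on the core of compound 1: the same change on two cores in this assay, a 2.4-fold lower number (0.37 log units; beyond the scatter) from compound 1 to compound 2 and an at least 2.0-fold lower number (0.30 log units; that floor lies within the scatter) from compound 3 to compound 4; the limit leaves it open whether they differ

Compound 3 stands at a limit of the assay, > 100000 nM, so the step to compound 4 is known only as a floor, and equal size on the two cores is not shown. Hydrogen in place of methyl on the oxygen gave a 1.4-fold higher number from compound 2 to compound 4 (0.13 log units; within the scatter), and that step can be set only against a floor on the other core: the same change on two cores in this assay, an at least 1.1-fold higher number (0.06 log units; that floor lies within the scatter) from compound 1 to compound 3 and a 1.4-fold higher number (0.13 log units; within the scatter) from compound 2 to compound 4; the limit leaves it open whether they differ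

On these data alone, whether the lower number carries over to other groups on the nitrogen, such as a phenyl bearing an amine or a carboxylic acid, remains open. Also open, as far as these compounds go, is how a longer chain on the oxygen would read.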